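Fluoro to hydrogen on the aryl bound to the ring amine

This account rests on a few compounds, and the source may have more. Where it says the series, first, only, none or still open, it means among the compounds named here.

Compound 1 `COc1ccc(N2CCN(c3nc(Nc4ccc(C#N)c(C(F)(F)F)c4)nc(Oc4ccnc5ccccc45)n3)CC2)cc1` and compound 2 `N#Cc1ccc(Nc2nc(Oc3ccnc4ccccc34)nc(N3CCN(c4ccccc4F)CC3)n2)cc1C(F)(F)F` share a core and differ only in the aryl group on an amine nitrogen in a ring. In a functional assay on DU-145 cells (Homo sapiens) for cytotoxicity, read by sulforhodamine B assay, with a stated time of 48 h (a higher number here means a weaker inhibitor of growth, a lower number a stronger inhibitor of growth), compound 1 gives only a limit, > 100000 nM. In this assay compound 2 likewise gives only a limit, > 100000 nM. The step that the two limits leave unreadable from compound 1 to compound 2 cannot be sized, as both values sit at the limit of > 100000 nM in this assay, at which 2 of the 2 values shown sit. Compound 3 `N#Cc1ccc(Nc2nc(Oc3ccnc4ccccc34)nc(N3CCN(c4ccccc4)CC3)n2)cc1C(F)(F)F` differs from compound 2 by hydrogen in place of fluoro on an aromatic carbon. Going by the values given here, no measured step informs this change. The step of a number no higher from compound 2 to compound 3 (the limit leaves the size open) is expected to stay within the scatter. Compound 3 is expected to give 100000 nM, within 30000 nM to 300000 nM.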

Compound 3, concentration for total growth inhibition: > 100000 nM
Compound 3: no number, only a limit; the forecaster's own chance of this, stated with the estimate: 85%; the middle value sits exactly at the limit.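

In this assay, going by these compounds alone, compound 1, compound 2 and compound 3 all give only a limit, and no step among them can be read. From the compounds shown here alone, whether the aryl group on the ring amine influences growth inhibition at all remains open.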